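The compounds below may be only part of what the source reports. "The series", "measured", "known", "first", "only" and "open" are said of these compounds alone.

Working notes on the series. Two compounds carry a number in a functional assay on the whole organism (strain Wistar) for inhibition, with Rattus norvegicus as the target, read by paw edema, with a stated time of 4 h, at a dose of 10 mg/kg by the oral route; on this read-out lower numbers stand for less inhibition and higher numbers for more inhibition at the one dose given (going by the name of the read-out). Compound 1 `Clc1ccc(-c2nnc(COc3ccc(-c4ccccc4)cc3)o2)cc1` gives 77.3% in this assay. Compound 2 `CCCCn1c(S)nnc1COc1ccc(-c2ccccc2)cc1` gives 81.8% in this assay. On these two numbers compound 2 sits level with compound 1, the gap between them within the usual scatter of this assay, so neither can be set above the other.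

Compound 3 `Cc1ccc(-n2c(S)nnc2COc2ccc(-c3ccccc3)cc2)c(C)c1` has not yet been measured in this assay. It differs from compound 2 in one place: 2,4-dimethylphenyl in place of butyl on an aromatic nitrogen. Among the compounds with values here, no step between measured compounds of this kind is available, so the size of this change has to be estimated without a matching precedent. The expectation is a step from compound 2 to compound 3 of a number 3.8 percentage points lower from compound 2 to compound 3 (within the scatter) in this assay, that is, no move beyond the scatter in either direction. Compound 3 is expected to give 78% in this assay, with a range from 62% to 90%.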

Compound 3, a percentage reported as inhibition, in the whole organism at one dose (the size of the read-out at that dose, not a potency): 54.5%
Compound 3: the middle estimate sits 23.5 percentage points above what was measured; measured number outside the range, below it.
By their numbers in this assay, from the lowest: compound 3; then compounds 1 and 2 (each within the scatter of the next).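

Within the data shown here, at this position on the aromatic nitrogen, the group matters in this assay: the change gives a number 27.3 percentage points lower from compound 2 to compound 3 (beyond the scatter), the only step on hand and one that lies beyond the scatter. The drop comes with butyl, a chain with no ring, leaving and 2,4-dimethylphenyl, with its six-membered aromatic ring of carbon only, entering, though this single exchange cannot separate the effect of the ring from that of its two methyl groups or of the larger group overall. No measurement available bears on the reason for this drop.

As far as these compounds go, it remains open whether an unsubstituted phenyl, a benzyl or a longer chain such as hexyl on this nitrogen would read closer to compound 2 or to compound 3. A single dose also leaves open whether the step would hold at other doses.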